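A few compounds are considered here, and "the series" means these few. Any claim that something is new, unique, unknown or untested is made for them only; others in the source may bear on it.

Measured in an ADME assay on microsomes from liver (Homo sapiens) for metabolic stability, read by LC-MS, with a stated time of 10 min; on this read-out lower numbers stand for a less stable compound and higher numbers for a more stable compound:
- compound 1 `c1cnc2c(c1)CCC[C@@H]2N(CC1CC1)C[C@H]1Cc2c(cccc2N2CCNCC2)CN1`: 82.1%
- compound 2 `FC1(F)CCC(CN(C[C@H]2Cc3c(cccc3N3CCNCC3)CN2)[C@H]2CCCc3cccnc32)CC1`: 68.6%

Of these two, compound 2 has the lower number, at 68.6%. The next compound to be tested is compound 3 `CCN(C[C@H]1Cc2c(cccc2N2CCNCC2)CN1)[C@H]1CCCc2cccnc21`, which differs from compound 2 in one place: methyl in place of 4,4-difluorocyclohexyl on a saturated chain carbon bound to an amine nitrogen. Thus compound 3 carries methyl where compound 2 carries 4,4-difluorocyclohexyl.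

Going by the values given here, only one measured step bears on this: a number 13.5 percentage points lower from compound 1 to compound 2 (beyond the scatter). There, 4,4-difluorocyclohexyl replaced cyclopropyl at that same place, and the drop was modest but beyond the scatter. Among the compounds with values here, removing 4,4-difluorocyclohexyl again is therefore expected to give a rise of similar size in this assay, although no measurement yet compares methyl with cyclopropyl. The expected change is a number 14.4 percentage points higher from compound 2 to compound 3 (beyond the scatter). For compound 3 the estimated value is 83%, with a range of 71% to 95%.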

Compound 3, percent of the compound remaining: 79.1%
The estimate for compound 3 lay 3.9 percentage points above the measured number, and the stated range covers the measured number.
By their numbers in this assay, from the lowest: compound 2; then compounds 3 and 1 (each within the scatter of the next).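

In this assay, methyl in place of 4,4-difluorocyclohexyl on a saturated chain carbon bound to an amine nitrogen gives a number 10.5 percentage points higher from compound 2 to compound 3 (beyond the scatter), so the change seen earlier also appears against a second small group. Methyl in place of cyclopropyl gives a number 3 percentage points lower from compound 1 to compound 3 (within the scatter), so these two groups cannot be told apart here, and among the three groups shown only 4,4-difluorocyclohexyl stands apart. Nothing measured here gives a cause for these steps.

Still open, on these data alone, is whether the lower number of compound 2 goes with the carbon ring or with its fluorine atoms, which a plain cyclohexyl at this place could separate. Also open, as far as these compounds go, is how a group such as an amine or a carboxylic acid at this place would compare with methyl and cyclopropyl.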